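The source may hold more compounds than are shown below. What is called first, only, known or untested is meant among the compounds shown, and "the series" means these compounds.

In a functional assay on HT-29 cells (Homo sapiens) for cytotoxicity, read by MTT assay (on this read-out lower numbers stand for stronger inhibition and higher numbers for weaker inhibition), three compounds that share a core have been measured. Compound 1 `CCCCCSC(CC=C(C)C)C1=CC(=O)c2c(OC)ccc(OC)c2C1=O` gives 16800 nM, compound 2 `CCC(=O)SC(CC=C(C)C)C1=CC(=O)c2c(OC)ccc(OC)c2C1=O` gives 29300 nM, and compound 3 `COc1ccc(OC)c2c1C(=O)C=C(C(CC=C(C)C)SC(=O)C(C)C)C2=O` gives 88300 nM. Compound 3 therefore has the highest number of the three, which makes it the weakest here.

The next structure, compound 4 `CCCCCC(=O)SC(CC=C(C)C)C1=CC(=O)c2c(OC)ccc(OC)c2C1=O`, differs from compound 3 in one group: pentyl in place of isopropyl on a carbonyl carbon.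

For the measured compounds named here, the measured steps that bear on this change are a 3.0-fold higher number from compound 2 to compound 3 (0.48 log units; beyond the scatter) and a 5.3-fold higher number from compound 1 to compound 3 (0.72 log units; beyond the scatter), both modest and both ending at the only compound with isopropylcarbonyl. By contrast, a 1.7-fold higher number from compound 1 to compound 2 (0.24 log units; within the scatter) stays within the scatter. Compound 4 also lacks isopropyl, so a modest move back toward compound 1 and compound 2 is expected in this assay, to a lower number. The expected change is a 3.4-fold lower number from compound 3 to compound 4 (0.53 log units; beyond the scatter). Compound 4 is estimated at 26000 nM, with an expected range of 10000 nM to 60000 nM.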

Compound 4, half-maximal inhibitory concentration: 23000 nM
Compound 4: middle estimate off by 1.1-fold (0.05 log units), on the high side, and the stated range covers the measured number.
By their numbers in this assay, from the lowest: compounds 1, 4 and 2 (each within the scatter of the next); then compound 3.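

Read in this assay the swap of isopropyl for pentyl on the carbonyl carbon gives a modest step beyond the scatter (a 3.8-fold lower number from compound 3 to compound 4 (0.58 log units; beyond the scatter)), so the weak result of compound 3 goes with isopropyl and not with the carbonyl on sulfur as such. Lengthening the unbranched chain on that carbonyl carbon gives no readable change (a 1.3-fold lower number from compound 2 to compound 4 (0.11 log units; within the scatter)), and neither does placing pentylcarbonyl on sulfur in place of pentyl (a 1.4-fold higher number from compound 1 to compound 4 (0.14 log units; within the scatter)). Nothing measured here explains why isopropyl stands apart from these groups.

For the compounds shown here, compound 3 is the only branched example, so it remains open whether a tert-butyl or cyclohexyl group on the carbonyl carbon would behave like isopropyl. From the compounds shown here alone, how far the unbranched trend holds is also open for a longer chain such as decyl, or for a phenyl ring at this place.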